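The source may report more compounds than this note shows. Statements on the series, on what has been measured and on what is new or still open speak of the compounds shown alone.

Measured so far in a functional assay on HeLa cells (Homo sapiens) for cytotoxicity, read by MTT assay, with a stated time of 72 h; a lower number here means a stronger inhibitor, a higher number a weaker inhibitor:
compound 1 `COc1ccc(C(=O)c2cc(OC)c(OC)c(OC)c2)cc1NC(=O)/C=C/c1ccc(C(F)(F)F)cc1`, 90 nM
compound 2 `COc1ccc(/C=C/C(=O)Nc2cc(C(=O)c3cc(OC)c(OC)c(OC)c3)cc(OC)c2OC)cc1`, 11200 nM
compound 3 `COc1cc(C(=O)c2cc(OC)c(OC)c(OC)c2)cc(NC(=O)/C=C/c2ccc(F)cc2)c1OC`, 900 nM

Compound 3 holds the second highest of the three numbers, with compound 1 well below it and compound 2 well above it. Compound 4 `COc1cc(C(=O)c2cc(OC)c(OC)c(OC)c2)cc(NC(=O)/C=C/c2ccc(C(F)(F)F)cc2)c1OC` differs from compound 3 by trifluoromethyl in place of fluoro on an aromatic carbon. For the measured compounds named here, the one step that bears on this position is a 12-fold lower number from compound 2 to compound 3 (1.09 log units; beyond the scatter), where methoxy gave way to fluoro and the number fell sharply. Going by the values given here, no step compares trifluoromethyl with fluoro directly; compound 1, which carries the trifluoromethyl group on a different core, shows the lowest number of the three, while compound 3 with fluoro sits above it. A further fall of moderate size is therefore expected in this assay, a 3.0-fold lower number from compound 3 to compound 4 (0.48 log units; beyond the scatter). Compound 4 is estimated at 300 nM, range 100 nM to 900 nM.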

Compound 4, half-maximal inhibitory concentration: 3000 nM
Beside the measured number, compound 4's estimate is 10-fold (1.00 log units) below it, outside the stated range (above it).
By their numbers in this assay, from the lowest: compound 1; then compound 3; then compound 4; then compound 2.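

In this assay, on the shared core, trifluoromethyl at this position does not match fluoro (a 3.3-fold higher number from compound 3 to compound 4 (0.52 log units; beyond the scatter)) but still improves on methoxy (a 3.7-fold lower number from compound 2 to compound 4 (0.57 log units; beyond the scatter)), so the order here runs fluoro, trifluoromethyl, methoxy. With trifluoromethyl held fixed, the added methoxy makes the largest step (a 33-fold higher number from compound 1 to compound 4 (1.52 log units; beyond the scatter)), so the low number of compound 1 does not carry over to the shared core. No measurement here accounts for these steps.

From the compounds shown here alone, whether chloro, a nitrile or an amine at this position would fall below fluoro stays open, as does whether this order holds on the core of compound 1.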